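Chloro in Place of Nitro on the Shared Core

The compounds below may be only part of what the source reports. "The series", "measured", "known", "first", "only" and "open" are said of these compounds alone.

Measured so far:
compound 1 `O=C(/C=C/OC1=CC=C1)Nc1nc2ccc(Cl)cc2s1` gives 544 umol/kg
compound 2 `COc1ccc(/C=C/C(=O)Nc2nc3ccc(Cl)cc3s2)cc1` gives 259 umol/kg
compound 3 `O=C(/C=C/c1ccc(O)cc1)Nc1nc2ccc([N+](=O)[O-])cc2s1` gives 382 umol/kg

These values come from a functional assay on the whole organism (Hindlimb, strain albino) with Mus musculus as the target, in the maximal electroshock model, with a stated time of 0.5 h; on this read-out lower numbers stand for an effect already at smaller amounts and higher numbers for an effect only at larger amounts of compound. Compound 3 holds the second highest of the three numbers. Its nearest neighbour is compound 1, whose number is higher by a margin that stays within the scatter; its furthest is compound 2, whose number is lower, again within the scatter. Taken together, the three compounds do not separate from one another on this assay.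

Compound 4 `O=C(/C=C/c1ccc(O)cc1)Nc1nc2ccc(Cl)cc2s1` has not yet been measured. It differs from compound 3 in one place: chloro in place of nitro on an aromatic carbon. The rest of the structure is unchanged.

Going by the values given here, no pair of measured compounds differs by this change alone, so there is no step to lean on. Compound 1 and compound 2 both carry chloro at the same place and sit within the scatter of compound 3, which suggests that the exchange is unlikely to move the number beyond the scatter. The step from compound 3 to compound 4 is therefore expected to be about a 1.1-fold lower number from compound 3 to compound 4 (0.04 log units; within the scatter), with no direction favoured.

For compound 4 the estimate is 350 umol/kg, in a range from 180 umol/kg to 700 umol/kg.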

Compound 4, dose for half-maximal effect: 322 umol/kg
Compound 4: middle estimate off by 1.1-fold (0.04 log units), on the high side, and the stated range covers the measured number.
By their numbers in this assay, from the lowest: compounds 2, 4, 3 and 1 (each within the scatter of the next, the first and the last beyond it).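

In this assay the exchange of nitro for chloro on this aromatic carbon can now be read directly, and the step is a 1.2-fold lower number from compound 3 to compound 4 (0.07 log units; within the scatter); at this position, with the rest of the structure held fixed, the two groups are not told apart. With chloro in place, the two other single-place exchanges stay within the scatter as well: hydrogen in place of methyl on the oxygen gives a 1.2-fold higher number from compound 2 to compound 4 (0.09 log units; within the scatter), and the group with the six-membered aromatic ring in place of the group with the four-membered non-aromatic ring gives a 1.7-fold lower number from compound 1 to compound 4 (0.23 log units; within the scatter). No measurement on these compounds bears on what lies behind these steps.

From the compounds shown here alone, the exchange of nitro for chloro rests on a single pair, so whether it reads the same alongside the side chains of compound 1 and compound 2 stays open. Also open, going by these compounds, is whether another group on this aromatic carbon, such as an amine or a carboxylic acid, would move the number beyond the scatter.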